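Carrying a Methoxy-to-Isobutoxy Change onto Compound 3

The source may hold more compounds than are shown below. What is called first, only, known or untested is meant among the compounds shown, and "the series" means these compounds.

Compound 1 `COc1ccc(-c2nc3cc(/C=C4\SC(=O)NC4=O)ccc3[nH]2)cc1OC` and compound 2 `COc1cc(-c2nc3cc(/C=C4\SC(=O)NC4=O)ccc3[nH]2)ccc1OCC(C)C` differ in a single place: isopropyl in place of hydrogen on a saturated chain carbon bound to an oxygen on an aromatic ring. In a functional assay on HT-1080 cells (Homo sapiens) for inhibition, read by MTT assay, with a stated time of 48 h (on this read-out lower numbers stand for stronger inhibition and higher numbers for weaker inhibition), compound 1 gives 2430 nM, and in this assay compound 2 gives 4450 nM, so the step is a 1.8-fold higher number from compound 1 to compound 2 (0.26 log units; within the scatter). Compound 3 `COc1ccc(-c2nc3cc(/C=C4\SC(=O)N(Cc5cc(OC)c(OC)c(OC)c5)C4=O)ccc3[nH]2)cc1OC` has a larger shared core than compound 1; how the two cores differ is not broken down here. In this assay, within the data shown here, compound 3 gives 270 nM, the lowest of the three numbers measured so far, with compound 1 nearest to it and compound 2 furthest from it.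

Compound 4 `COc1cc(-c2nc3cc(/C=C4\SC(=O)N(Cc5cc(OC)c(OC)c(OC)c5)C4=O)ccc3[nH]2)ccc1OCC(C)C` has not yet been measured. It stands to compound 3 exactly as compound 2 stands to compound 1: isopropyl in place of hydrogen on a saturated chain carbon bound to an oxygen on an aromatic ring. The place of the change reads the same in both pairs, so it is the same change, made the second time on the core of compound 3 rather than that of compound 1. Because the earlier pair showed a 1.8-fold higher number from compound 1 to compound 2 (0.26 log units; within the scatter), a step of similar size is expected in this assay, that is a 1.7-fold higher number from compound 3 to compound 4 (0.22 log units; within the scatter). This expectation rests on one measured pair only, and the step it produced lay within the scatter, so the direction itself is uncertain. Compound 4 is therefore expected to give 450 nM, with a likely range from 180 nM to 1200 nM.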

Compound 4, half-maximal inhibitory concentration: 160 nM
Compound 4: middle estimate off by 2.8-fold (0.45 log units), on the high side; the measured number lies below the stated range.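

In this assay, the methoxy-to-isobutoxy change on the core of compound 3 gives a 1.7-fold lower number from compound 3 to compound 4 (0.23 log units; within the scatter), so this step taken alone cannot be told apart from repeat-to-repeat variation. Set beside the earlier step on the core of compound 1, however, the same change does not give the same result on the two cores: the same change on two cores in this assay, a 1.8-fold higher number (0.26 log units; within the scatter) from compound 1 to compound 2 and a 1.7-fold lower number (0.23 log units; within the scatter) from compound 3 to compound 4, 3.1-fold (0.49 log units) apart, beyond the scatter of two such steps This shows that, in this series, the step measured on one core cannot simply be carried over as a fixed increment to the other, but it does not establish a true reversal of direction, since each step lies within the scatter on its own, and it offers no rule or explanation, as each core contributes only a single pair.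

The compounds shown leave open whether the gap between the two cores would also appear with other groups at the same place, such as an ethyl group, a longer chain, or a chain ending in an amine or a carboxylic acid. They also leave open whether further pairs on these two cores would bring the steps closer together or hold them apart, and whether the gap would persist in a read-out other than this assay.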